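The source may hold more compounds than are shown below. What is called first, only, known or untested is meant among the compounds shown, and "the series" means these compounds.

Measured compounds:
- compound 1 `O=C1N=C(N2N=C(c3ccccc3)CC2c2ccc(Cl)cc2)S/C1=C1\C(=O)Nc2ccccc21`: "not determined" (no result reported)
- compound 2 `COc1ccc(NC(=O)COc2ccc(Cl)cc2/C=C2\SC(=S)N(Nc3nc4ccccc4s3)C2=O)cc1`: 55300 nM

Compound 1 `O=C1N=C(N2N=C(c3ccccc3)CC2c2ccc(Cl)cc2)S/C1=C1\C(=O)Nc2ccccc21` was tested in a functional assay on Mino cells (Homo sapiens) for cytotoxicity, read by MTT assay, with a stated time of 72 h (on this read-out higher numbers stand for weaker inhibition and lower numbers for stronger inhibition), but no number was reported for it, so it has no place on this scale. Compound 2 `COc1ccc(NC(=O)COc2ccc(Cl)cc2/C=C2\SC(=S)N(Nc3nc4ccccc4s3)C2=O)cc1` is built on a different core, and in this assay compound 2 gives 55300 nM, a weak result. As the two compounds share no single point of difference, their values cannot be compared as a step, and nothing here says how the core of compound 1 performs.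

Going by the values given here, compound 3 `O=C1N=C(N2N=C(c3ccc(Cl)cc3)CC2c2ccc(Cl)cc2)S/C1=C1\C(=O)Nc2ccccc21` is the first compound with one change made: chloro in place of hydrogen on an aromatic carbon, on the ring para to a large group, which turns phenyl into 4-chlorophenyl. Among the compounds with values here, with no measured pair of this kind, the size of this step is unknown. A change of this sort in this assay often stays within the scatter, so no change beyond it is expected in either direction. With only the weak result of compound 2 as a guide, compound 3 is expected to give around 20000 nM, within a wide range from 3000 nM to 100000 nM.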

Compound 3, half-maximal inhibitory concentration: 68200 nM
For compound 3 the middle estimate is 3.4-fold (0.53 log units) below the measured one, and the stated range covers the measured number.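

In this assay compound 3 gives 68200 nM, but compound 1 has no number on this scale, so the change from phenyl to 4-chlorophenyl cannot be read as a step. The compounds shown leave open what this chloro group does to the result in these cells. No supporting data here bear on the value of compound 3.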